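Replacing the hydroxycarbamoyl group of compound 1

The compounds below may be only part of what the source reports. "The series", "measured", "known", "first", "only" and "open" are said of these compounds alone.

Values in a functional assay on HCT-116 cells (Homo sapiens) for antiproliferative activity, read by CCK-8 assay, with a stated time of 72 h; a higher number here means a weaker inhibitor, a lower number a stronger inhibitor:
compound 1 `CCOc1cc(C(C)(C)C)ccc1C1=NC(c2ccc(Cl)cc2)C(c2ccc(Cl)cc2)N1C(=O)NCCCCCCCC(=O)NO` gives 5030 nM
compound 2 `CCOc1cc(C(C)(C)C)ccc1C1=NC(c2ccc(Cl)cc2)C(c2ccc(Cl)cc2)N1C(=O)N1CCN(c2ncc(C(=O)NO)cn2)CC1` gives 980 nM
compound 3 `CCOc1cc(C(C)(C)C)ccc1C1=NC(c2ccc(Cl)cc2)C(c2ccc(Cl)cc2)N1C(=O)NCc1ccc(C(=O)NO)cc1` gives 9100 nM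

Compound 1 (5030 nM) carries a higher number than compound 2 (980 nM), and that gap lies beyond the scatter. Compound 1 is not separated from compound 3 on these numbers.

Compound 4 `CCOc1cc(C(C)(C)C)ccc1C1=NC(c2ccc(Cl)cc2)C(c2ccc(Cl)cc2)N1C(=O)NCCCCCC(=O)Nc1ccccc1N` has (2-aminophenyl)carbamoyl in place of 2-(hydroxycarbamoyl)ethyl on a saturated chain carbon, five bonds along the chain from an amide-type nitrogen. Among the measured compounds shown here, all three measured compounds carry a hydroxycarbamoyl group and none carries (2-aminophenyl)carbamoyl, so this exchange has no direct precedent.

The closest evidence is the exchange of 6-(hydroxycarbamoyl)hexyl for 4-(hydroxycarbamoyl)phenyl (a 1.8-fold higher number from compound 1 to compound 3 (0.26 log units; within the scatter)), which stays within the scatter. On these data alone, on that single step, no change beyond the scatter is expected in this assay, and the direction remains open, with a slightly higher number as the working guess. The expected step is small (a 1.2-fold higher number from compound 1 to compound 4 (0.08 log units; within the scatter)). As far as these compounds go, for compound 4 the estimated value is 6000 nM, with an expected range from 2000 nM to 18000 nM, kept wide since the new group is untested here.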

Compound 4, half-maximal inhibitory concentration: 21800 nM
Beside the measured number, compound 4's estimate is 3.6-fold (0.56 log units) below it; the whole stated range lies below it.
By their numbers in this assay, from the lowest: compound 2; then compounds 1 and 3 (each within the scatter of the next); then compound 4.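

In this assay, (2-aminophenyl)carbamoyl in place of 2-(hydroxycarbamoyl)ethyl, on a saturated chain carbon five bonds along the chain from an amide-type nitrogen, gives a 4.3-fold higher number from compound 1 to compound 4 (0.64 log units; beyond the scatter), so this change moves the number beyond the scatter, unlike the change of a 1.8-fold higher number from compound 1 to compound 3 (0.26 log units; within the scatter), which stays within it. The hydroxycarbamoyl end of compound 1 therefore cannot be exchanged for (2-aminophenyl)carbamoyl at this position without a cost in this assay, and the step does not follow the hydrogen-bond donor and acceptor counts, which are the same in the leaving and entering groups. Nothing measured on these compounds bears on the cause of this step.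

On these data alone, compound 4 differs from compound 1 in both its terminal group and its chain, which is shorter, so the share of each in the higher number remains open. A carboxylic acid on the chain of compound 1, a hydroxycarbamoyl group on the chain of compound 4, or (2-aminophenyl)carbamoyl on a longer chain would separate the two contributions.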